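The source may hold more compounds than are shown below. What is called first, only, known or untested is meant among the compounds shown, and "the series" means these compounds.

The measured compounds:
compound 1, `N#Cc1c(C2CCCCC2)nc(S)[nH]c1=O`, in an assay on isolated protein for inhibition of Rap guanine nucleotide exchange factor 4 (Homo sapiens), read by fluorescence and cAMP accumulation (a higher number here means a weaker inhibitor, a lower number a stronger inhibitor), gives > 300000 nM, which is a limit of the assay rather than a number.
compound 2, `Cc1ccc(CSc2nc(C3CCCCC3)c(C#N)c(=O)[nH]2)c(C)c1`, in this assay gives 15700 nM.

Among the measured compounds shown here, compound 2 holds the only actual number in this assay; the other value is a limit, (the limit of > 300000 nM in this assay, at which 1 of the 2 values shown sits). Compound 3, `N#Cc1c(C2CCCCC2)nc(SCc2ccccc2)[nH]c1=O`, has not yet been measured. It differs from compound 2 in one place: phenyl in place of 2,4-dimethylphenyl on a saturated chain carbon bound to a sulfur. For the measured compounds named here, no step between two measured compounds is available to guide this change, so the expectation rests on compound 2 alone, which gives 15700 nM in this assay. The step expected for compound 3 is a 1.6-fold higher number from compound 2 to compound 3 (0.20 log units; within the scatter), small and, if anything, toward a weaker inhibitor. Compound 3 is estimated at 25000 nM in this assay, with a range from 8000 nM to 80000 nM.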

Compound 3, half-maximal inhibitory concentration: 30500 nM
Compound 3: middle estimate off by 1.2-fold (0.09 log units), on the low side, and the stated range covers the measured number.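

Replacing 2,4-dimethylphenyl with phenyl on a saturated chain carbon bound to a sulfur gives a 1.9-fold higher number from compound 2 to compound 3 (0.29 log units; within the scatter) in this assay, so the two methyl groups of compound 2 make no measurable difference here. Adding the group on the sulfur does matter: benzyl in place of hydrogen gives an at least 9.8-fold lower number from compound 1 to compound 3 (0.99 log units; beyond the scatter). That step has no exact size, as the result for compound 1 is a limit and not a number: the limit of > 300000 nM in this assay, at which 1 of the 3 values shown sits.

The compounds shown leave open whether the aromatic ring is needed at all, or whether a simple ethyl group on the sulfur would serve as well. They also cannot say how a longer chain between the sulfur and the phenyl, or a chlorine or a carboxylic acid on that ring, would change the result.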